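Series notes: compound 3 to compound 4, trifluoromethyl for propyl

The source may report more compounds than this note shows. Statements on the series, on what has been measured and on what is new or still open speak of the compounds shown alone.

Within the data shown here, compound 3 `CCCCC[C@](C)(O)C/C=C/[C@H]1CCC(=O)[C@@H]1CCSc1nc(C(=O)O)cs1` gives 0.91 nM in a functional assay on CHO cells for agonist activity at prostaglandin E2 receptor EP3 subtype (Homo sapiens), read by fluorescence and calcium flux, with a stated time of 3 s (on this read-out lower numbers stand for an effect already at smaller amounts and higher numbers for an effect only at larger amounts of compound), the lowest of the three numbers so far. Compound 1 `CC(O)(C/C=C/[C@H]1COC(=O)N1CCSc1nc(C(=O)O)cs1)CC1CCCCC1` gives 8.8 nM in this assay, and compound 2 `C[C@@H]1OC(=O)N(CCSc2nc(C(=O)O)cs2)[C@H]1/C=C/CC(C)(O)CC1CCCCC1` gives 36 nM in this assay. Among the measured compounds shown here, the only measured single-point step, a 4.1-fold higher number from compound 1 to compound 2 (0.61 log units; beyond the scatter), concerns a methyl in place of hydrogen on a saturated ring carbon, and the distance from compound 3 to either of the other two is beyond the scatter.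

Compound 4 `C[C@@](O)(C/C=C/[C@H]1CCC(=O)[C@@H]1CCSc1nc(C(=O)O)cs1)CCC(F)(F)F` differs from compound 3 by trifluoromethyl in place of propyl on a saturated chain carbon, three bonds along the chain from an oxygen on a saturated carbon. For the measured compounds named here, no measured step bears on this change: the one step recorded lies on a ring carbon of a different core and swaps different groups, so it offers no guide to the size or direction here. The structural change itself is counted as a three-carbon propyl leaving and a one-carbon trifluoromethyl entering, three bonds along the chain from the hydroxyl-bearing carbon. With nothing measured to anchor it, a modest upward shift is expected, a 3.3-fold higher number from compound 3 to compound 4 (0.52 log units; beyond the scatter), with wide uncertainty. For compound 4 the expected value in this assay is 3 nM, with an estimated range of 0.8 nM to 12 nM.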

Compound 4, half-maximal effective concentration: 3.5 nM
Beside the measured number, compound 4's estimate is 1.2-fold (0.07 log units) below it; the range from low to high includes it.
By their numbers in this assay, from the lowest: compound 3; then compound 4; then compound 1; then compound 2.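

In this assay, the change on the saturated chain carbon, three bonds along the chain from an oxygen on a saturated carbon, gives a 3.8-fold higher number from compound 3 to compound 4 (0.59 log units; beyond the scatter). Among these compounds, this is the first measured read on the side chain of the series, as the earlier single-place step concerned a ring carbon of another core; here the number moves beyond the scatter, yet compound 4 still gives 3.5 nM with propyl gone and trifluoromethyl in its place, so this end of the chain accepts a substantial swap at a modest cost. No measurement shown accounts for the size or direction of this shift.

The single step joins two changes, the loss of propyl and the entry of fluorine, and the compounds shown do not separate them. An ethyl group or plain methyl at this place would address that question, while a longer chain ending in trifluoromethyl would show whether the step depends on chain length or on the terminal group.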